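A few compounds are considered here, and "the series" means these few. Any claim that something is new, unique, unknown or untested is made for them only; others in the source may bear on it.

Working notes on the series.

Compound 1, `COc1cccc(Cc2cn(C3CC3)c3c(F)c(-c4cc(C)nc(C)c4)c(F)cc3c2=O)c1`, is tested in a functional assay on P388 cells (Mus musculus) for cytotoxicity (a higher number here means a weaker inhibitor, a lower number a stronger inhibitor), where compound 1 gives 20000 nM. Compound 2, `Cc1cc(-c2c(F)cc3c(=O)c(Cc4ccc(Cl)cc4)cn(C4CC4)c3c2F)cc(C)n1`, gives 20000 nM in this assay, and compound 3, `Cc1cc(-c2c(F)cc3c(=O)c(Cc4ccccc4O)cn(C4CC4)c3c2F)cc(C)n1`, gives 670 nM. Compound 1 thus stands level with compound 2, the two together the highest of the three numbers, with compound 3 the furthest from compound 1.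

The step from compound 1 to compound 2, no change at the digits printed from compound 1 to compound 2 (within the scatter), shows that 4-chlorophenyl for 3-methoxyphenyl moves nothing. The step to compound 3, a 30-fold lower number from compound 1 to compound 3 (1.47 log units; beyond the scatter), and the matching step a 30-fold lower number from compound 2 to compound 3 (1.47 log units; beyond the scatter), show that 2-hydroxyphenyl at the same place brings a large drop.

Compound 4 is `Cc1cc(-c2c(F)cc3c(=O)c(Cc4ccc(O)cc4)cn(C4CC4)c3c2F)cc(C)n1`. From compound 1 the change is 4-hydroxyphenyl in place of 3-methoxyphenyl on a saturated chain carbon bound to an aromatic carbon. Among the measured compounds shown here, this brings a hydroxyphenyl, as in compound 3, though as 4-hydroxyphenyl rather than 2-hydroxyphenyl, so only one step of the three bears on it directly. A lower number is expected for compound 4, but smaller than the step to compound 3 because of a 30-fold lower number from compound 1 to compound 3 (1.47 log units; beyond the scatter) being tied to the 2-hydroxyphenyl pattern alone. Compound 4 is therefore estimated at 3000 nM, within 600 nM to 20000 nM, an expected step of a 6.7-fold lower number from compound 1 to compound 4 (0.82 log units; beyond the scatter).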

Compound 4, half-maximal inhibitory concentration: 1500 nM
The estimate for compound 4 lay 2.0-fold (0.30 log units) above the measured number; the measured number falls inside the stated range.
By their numbers in this assay, from the lowest: compound 3; then compound 4; then compounds 1 and 2 (each within the scatter of the next).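

In this assay, the large drop no longer belongs to 2-hydroxyphenyl alone: 4-hydroxyphenyl also gives a 13-fold lower number from compound 1 to compound 4 (1.12 log units; beyond the scatter), and hydroxy in place of chloro on an aromatic carbon gives a 13-fold lower number from compound 2 to compound 4 (1.12 log units; beyond the scatter). The two hydroxyphenyl groups still differ, but only modestly (a 2.2-fold higher number from compound 3 to compound 4 (0.35 log units; beyond the scatter)), so among these four compounds the two that carry a hydroxy have the lowest numbers, and none goes against this. Nothing available gives a reason for these differences.

Since compound 1 differs from compound 4 in both the group on the ring and where it stands, the two changes cannot be separated, and 3-hydroxyphenyl would be the direct comparison with 3-methoxyphenyl. From the compounds shown here alone, whether an aminophenyl or a carboxylic acid on the same ring would also lower the number remains open.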